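The source may hold more compounds than are shown below. What is called first, only, known or untested is meant among the compounds shown, and "the series" means these compounds.

Measured compounds:
Compound 1, `O=C1NCCN1c1ccc(S(=O)(=O)Nc2cccc(Br)c2)cc1`: 59 nM
Compound 2, `CCc1ccc(NS(=O)(=O)c2ccc(N3CCNC3=O)cc2)cc1`: 480 nM
Compound 3, `O=C1NCCN1c1ccc(S(=O)(=O)Nc2ccc(OC(F)F)cc2)cc1`: 410 nM

In a functional assay on M21 cells (Homo sapiens) for antiproliferative activity, read by sulforhodamine B assay, with a stated time of 48 h (a lower number here means a stronger inhibitor, a higher number a weaker inhibitor), compound 3 gives 410 nM, the second highest of the three numbers. Its nearest neighbour is compound 2 at 480 nM, a gap within the scatter, while compound 1 at 59 nM lies furthest away, with an 8.1-fold higher number from compound 1 to compound 2 (0.91 log units; beyond the scatter) separating compounds 1 and 2 when 4-ethylphenyl replaces 3-bromophenyl on the sulfonamide nitrogen. The step from compound 2 to compound 3, difluoromethoxy in place of ethyl on an aromatic carbon, was a 1.2-fold lower number from compound 2 to compound 3 (0.07 log units; within the scatter).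

Compound 4, `O=C1NCCN1c1ccc(S(=O)(=O)Nc2ccc(Br)cc2)cc1`, differs from compound 3 in this way: bromo in place of difluoromethoxy on an aromatic carbon. Among the measured compounds shown here, no measured step exchanges difluoromethoxy for bromo on this ring. For the measured compounds named here, the only measured change on that aromatic carbon, from compound 2 to compound 3, stayed within the scatter. The bromo group appears in compound 1, the strongest inhibitor here, though there it sits on a different carbon. He therefore expects a modest lowering for compound 4, a 2.1-fold lower number from compound 3 to compound 4 (0.31 log units; beyond the scatter), and estimates 200 nM with a range from 70 nM to 600 nM.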

Compound 4, half-maximal inhibitory concentration: 130 nM
Compound 4: the middle estimate sits 1.5-fold (0.19 log units) above what was measured, and the stated range covers the measured number.
By their numbers in this assay, from the lowest: compound 1; then compound 4; then compounds 3 and 2 (each within the scatter of the next).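

On this aromatic carbon, para to a large group, ethyl and difluoromethoxy had been indistinguishable in this assay, but bromo separates from both, with a 3.2-fold lower number from compound 3 to compound 4 (0.50 log units; beyond the scatter) and a 3.7-fold lower number from compound 2 to compound 4 (0.57 log units; beyond the scatter) as the two steps. The place of the bromine also matters, since 4-bromophenyl in place of 3-bromophenyl on the sulfonamide nitrogen gives a 2.2-fold higher number from compound 1 to compound 4 (0.34 log units; beyond the scatter) and the 3-bromophenyl compound keeps the lowest number of the four. Nothing available explains why bromo differs from the other two groups.

The compounds shown leave open whether chloro or a nitrile on this carbon would behave like bromo, and whether an amine or a carboxylic acid there would be tolerated. They also leave open whether ethyl or difluoromethoxy would gain from the same shift of place that favours bromine.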